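Aminophenoxy isomers in the series

The compounds below may be only part of what the source reports. "The series", "measured", "known", "first", "only" and "open" are said of these compounds alone.

In a functional assay on HeLa cells (Homo sapiens) for antiproliferative activity, read by cell counting, with a stated time of 3 days (a lower number here means a stronger inhibitor, a higher number a weaker inhibitor), compound 1 (`CC(Nc1ccccc1Oc1cccc(F)c1)=C1C(=O)CC(c2ccccc2)CC1=O`) gives 550 nM, compound 2 (`COc1cc(Oc2ccccc2NC(C)=C2C(=O)CC(c3ccccc3)CC2=O)ccc1N`) gives 33 nM and compound 3 (`CC(Nc1ccccc1Oc1cccc(N)c1)=C1C(=O)CC(c2ccccc2)CC1=O`) gives 82 nM. Compound 3 therefore holds the middle of the three numbers. Compound 4 (`CC(Nc1ccccc1Oc1ccc(N)cc1)=C1C(=O)CC(c2ccccc2)CC1=O`) differs from it as follows: 4-aminophenyl in place of 3-aminophenyl on an oxygen on an aromatic ring. Two amino-bearing replacements of the 3-fluorophenyl group lowered the number: a 6.7-fold lower number from compound 1 to compound 3 (0.83 log units; beyond the scatter) and a 17-fold lower number from compound 1 to compound 2 (1.22 log units; beyond the scatter). Closest to the new group is 4-amino-3-methoxyphenyl, with a 2.5-fold higher number from compound 2 to compound 3 (0.40 log units; beyond the scatter). For the measured compounds named here, no measured compound shows the 4-aminophenyl group without the methoxy. The expected change in this assay is a 1.6-fold lower number from compound 3 to compound 4 (0.21 log units; within the scatter), leaning lower but not beyond the scatter. Compound 4 is estimated at 50 nM, with an expected range of 17 nM to 150 nM.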

Compound 4, half-maximal inhibitory concentration: 39 nM
For compound 4 the middle estimate is 1.3-fold (0.11 log units) above the measured one, within the range that was stated.
By their numbers in this assay, from the lowest: compounds 2 and 4 (each within the scatter of the next); then compound 3; then compound 1.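

In this assay, moving the amino group alone, 3-aminophenyl to 4-aminophenyl with the same atoms, gives a 2.1-fold lower number from compound 3 to compound 4 (0.32 log units; beyond the scatter), so the position of the amino group matters in its own right. The methoxy of compound 2 is not required for this level: hydrogen in its place gives a 1.2-fold higher number from compound 2 to compound 4 (0.07 log units; within the scatter). The 4-aminophenyl group alone also accounts for a 14-fold lower number from compound 1 to compound 4 (1.15 log units; beyond the scatter), relative to the 3-fluorophenyl group.

No data at hand explain the effect of the position. Going by these compounds, whether a hydroxyl or a dimethylamino group in place of the amino would hold this level remains open.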